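Removing the Bromo Group from Compound 2

This account rests on a few compounds, and the source may have more. Where it says the series, first, only, none or still open, it means among the compounds named here.

Two related compounds have been measured so far. In a functional assay on CCRF-CEM cells (Homo sapiens) for antiproliferative activity, read by cell counting, with a stated time of 72 h (on this read-out higher numbers stand for weaker inhibition and lower numbers for stronger inhibition), compound 1 (`C#C[C@@]1(O)[C@@H](CO)O[C@@H](n2cc(Br)c3c(N)ncnc32)[C@@H]1O`) gives 30 nM while compound 2 (`C#C[C@@]1(O)[C@@H](CO)O[C@@H](n2cc(Br)c3c(Cl)ccnc32)[C@@H]1O`) gives 560 nM as its reading. Compound 2 therefore has the higher number of the two, which means weaker inhibition, and the gap between them lies beyond the usual scatter. The next compound, compound 3 (`C#C[C@@]1(O)[C@@H](CO)O[C@@H](n2ccc3c(Cl)ccnc32)[C@@H]1O`), differs from compound 2 by having hydrogen in place of bromo on an aromatic carbon. For the measured compounds named here, no measured pair shows the effect of this change alone, so any forecast is uncertain. In this assay a modest move towards weaker inhibition is expected, only slightly beyond the scatter, with an estimated 2.7-fold higher number from compound 2 to compound 3 (0.43 log units; beyond the scatter) as the likely step. For compound 3 the estimated value is 1500 nM with an expected range from 300 nM to 8000 nM around that figure.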

Compound 3, half-maximal inhibitory concentration: 86000 nM
For compound 3 the middle estimate is 57-fold (1.76 log units) below the measured one, outside the stated range (above it).
By their numbers in this assay, from the lowest: compound 1; then compound 2; then compound 3.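

In this assay, the bromo group on this aromatic carbon of the five-membered ring proves to matter greatly: hydrogen in its place gives a 150-fold higher number from compound 2 to compound 3 (2.19 log units; beyond the scatter), a large loss of inhibition. For the compounds shown here, this is the first pair that differs in only one place, so it gives the first direct reading of this position, and it shows that losing a single heavy atom is enough for a step of this size. No measurement available here accounts for why the step is so large.

Going by these compounds, it remains open whether bromo itself is needed, or whether another group on the same carbon, such as methyl or a nitrile, would keep the inhibition. Also open, on these data alone, is whether hydrogen in place of bromo would cost as much on the core of compound 1.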